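A few compounds are considered here, and "the series" means these few. Any claim that something is new, unique, unknown or untested is made for them only; others in the source may bear on it.

Measured in an ADME assay on MT4 cells (Homo sapiens) for cytotoxicity, read by MTT assay, with a stated time of 4 days; a higher number here means that more compound is tolerated, a lower number that less compound is tolerated: compound 1 `COc1ccccc1-c1cc(=O)c2cc(NC(C)=O)ccc2o1` gives 226000 nM; compound 2 `CC(=O)Nc1ccc2oc(-c3ccccc3F)cc(=O)c2c1` gives 205000 nM; compound 3 `COc1ccc(-c2oc3ccc(N)cc3c(=O)c2O)cc1` gives 239000 nM.

Compound 1 and compound 2 differ by one change, (fluoro in place of methoxy on an aromatic carbon), and this change made a 1.1-fold lower number from compound 1 to compound 2 (0.04 log units; within the scatter). How the core of compound 3 differs from that of compound 1 is not broken down here. Compound 4 `Nc1ccc2oc(-c3ccc(F)cc3)c(O)c(=O)c2c1` differs from compound 3 by fluoro in place of methoxy on an aromatic carbon. Within the data shown here, this is the same kind of change as the one from compound 1 to compound 2, but not the same: in compound 2 the fluoro sits ortho to a large group, in compound 4 it sits para to a large group. Because a 1.1-fold lower number from compound 1 to compound 2 (0.04 log units; within the scatter) stayed within the scatter, a step of similar size is expected here, a 1.1-fold lower number from compound 3 to compound 4 (0.05 log units; within the scatter). Compound 4 is therefore estimated at 215000 nM in this assay, between 120000 nM and 380000 nM.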

Compound 4, half-maximal cytotoxic concentration: 92600 nM
Compound 4: middle estimate off by 2.3-fold (0.37 log units), on the high side; the measured number lies below the stated range.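

In this assay, fluoro in place of methoxy, para to a large group, gave a 2.6-fold lower number from compound 3 to compound 4 (0.41 log units; beyond the scatter). Set beside the earlier step, this one does not differ from it by more than the scatter of two such steps allows: the same change on two cores in this assay, a 1.1-fold lower number (0.04 log units; within the scatter) from compound 1 to compound 2 and a 2.6-fold lower number (0.41 log units; beyond the scatter) from compound 3 to compound 4, 2.3-fold (0.37 log units) apart, within the scatter of two such steps. Among these compounds, this gives no sign that the size of the step depends on the core, but it does not establish that the step carries over, as it rests on only two pairs, and the fluoro sits in a different place in each. The compounds shown leave open how a chloro or a hydroxyl group in the place of the methoxy would compare. They also leave open whether fluoro in one and the same place would give matching steps on both cores.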